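Nitro for hydroxy on both cores of the urea series

The source may hold more compounds than are shown below. What is called first, only, known or untested is meant among the compounds shown, and "the series" means these compounds.

Measured in a functional assay on K562 cells (Homo sapiens) for antiproliferative activity, read by MTT assay, with a stated time of 48 h; on this read-out higher numbers stand for weaker inhibition and lower numbers for stronger inhibition:
Compound 1 `CN(C)C(=O)N(Cc1ccc(O)cc1)Cc1ccco1` gives 18600 nM.
Compound 2 `CCOC(=O)N1CCC(N(Cc2ccc(O)cc2)C(=O)N(C)C)CC1` gives 41800 nM.
Compound 3 `CN(C)C(=O)N(Cc1ccc([N+](=O)[O-])cc1)Cc1ccco1` gives 35400 nM.

Compound 4 `CCOC(=O)N1CCC(N(Cc2ccc([N+](=O)[O-])cc2)C(=O)N(C)C)CC1` is not yet measured. The difference between the two cores, that of compound 1 and that of compound 2, is not broken down here. Compound 3 carries nitro in place of hydroxy on an aromatic carbon relative to compound 1, and the step is a 1.9-fold higher number from compound 1 to compound 3 (0.28 log units; within the scatter). Compound 4 stands to compound 2 as compound 3 stands to compound 1: it carries nitro in place of hydroxy on an aromatic carbon. The place of the change reads the same on both cores, so this is the same kind of change made on a different core; whether the second core answers alike cannot be known from three numbers. Compound 2 and compound 3 lie within the scatter of each other, while compound 2 gives a higher number than compound 1, beyond the scatter. For compound 4 in this assay the expected step from compound 2 is a 1.7-fold higher number from compound 2 to compound 4 (0.22 log units; within the scatter), because a 1.9-fold higher number from compound 1 to compound 3 (0.28 log units; within the scatter) is the only measured occurrence of this change and is small. Compound 4 is therefore estimated at 70000 nM, with a range of 30000 nM to 160000 nM.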

Compound 4, half-maximal inhibitory concentration: 26000 nM
The estimate for compound 4 lay 2.7-fold (0.43 log units) above the measured number, outside the stated range (below it).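

In this assay, nitro in place of hydroxy on the second core gives a 1.6-fold lower number from compound 2 to compound 4 (0.21 log units; within the scatter). Set beside the earlier step, the change does not carry from one core to the other with the same direction or size: the same change on two cores in this assay, a 1.9-fold higher number (0.28 log units; within the scatter) from compound 1 to compound 3 and a 1.6-fold lower number (0.21 log units; within the scatter) from compound 2 to compound 4, 3.1-fold (0.49 log units) apart, beyond the scatter of two such steps. Within the data shown here, each step alone stays within the scatter, so neither one shows on its own that nitro and hydroxy differ on its core; the two pairs show only that a step read on one core was a poor guide to the other, and they do not show what in the cores sets the steps apart.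

Open, on these data alone, is whether an amine or a carboxylic acid in place of hydroxy on the same aromatic carbon would also answer differently on the two cores. Open too, as far as these compounds go, is whether the gap between the steps would hold on a third core, since two pairs give no general rule for this series.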